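Removing a fluoro from the aryl group of compound 1

The source may report more compounds than this note shows. Statements on the series, on what has been measured and on what is new or still open speak of the compounds shown alone.

Compound 1 `O=C(Nc1cc(F)c(F)c(F)c1)N1Cc2c(-c3ccc(F)cc3F)cnn2CC1C1CC1` is the reference point of this set. In a toxicity assay on HepG2 2.2.15 cells (Homo sapiens) for cytotoxicity, read by CellTiter-Glo (a lower number here means that less compound is tolerated, a higher number that more compound is tolerated), compound 1 gives 32100 nM, the highest of the two numbers recorded, and that of compound 3 `O=C1OC(c2ccc(F)cc2)CN1c1cnn2c1CN(C(=O)Nc1cc(F)c(F)c(F)c1)C(C1CC1)C2`, which gives 3560 nM, is lower by a gap beyond the scatter. Compound 2 `C[C@H]1Cn2ncc(N3CC(c4ccccc4)CC3=O)c2CN1S(=O)(=O)Nc1cc(F)c(F)c(F)c1` is recorded only as a limit of the assay, > 2000 nM; this is the limit of > 2000 nM in this assay, at which 1 of the 3 values shown sits, so it sets no number against the other two.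

The compound to be measured is compound 4 `O=C(Nc1cc(F)c(F)c(F)c1)N1Cc2c(-c3ccc(F)cc3)cnn2CC1C1CC1`. It differs from compound 1 in one place: hydrogen in place of fluoro on an aromatic carbon. Going by the values given here, no measured pair in this set shows the same change, so there is no step to lean on. A single fluoro leaving an aromatic carbon is a small change for a cytotoxicity read-out of this kind, and compound 1 gives a full number, 32100 nM, in this assay.

The expectation is that the step of a 1.1-fold lower number from compound 1 to compound 4 (0.06 log units; within the scatter) stays within the scatter, with no preferred direction. Compound 4 is thus estimated at 28000 nM, with a range from 12000 nM to 60000 nM; compound 3 alone shows how far a different change at the same region can pull the number down.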

Compound 4, half-maximal cytotoxic concentration: 38500 nM
Compound 4: the middle estimate sits 1.4-fold (0.14 log units) below what was measured, and the stated range covers the measured number.
By their numbers in this assay, from the lowest: compound 3; then compounds 1 and 4 (each within the scatter of the next).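

Going by these compounds alone, the 2,4-difluorophenyl to 4-fluorophenyl change supplies the first step in this set between compounds that differ in one place: in this assay, the step is a 1.2-fold higher number from compound 1 to compound 4 (0.08 log units; within the scatter). Compounds 1 and 4 therefore cannot be told apart in this read-out, and the tolerated concentration seen for compound 1 does not depend on the fluoro on this aromatic carbon, ortho to a large group, since hydrogen serves equally well there. The data shown offer no measured property that bears on this result.

Going by these compounds, this single step covers only the exchange of fluoro for hydrogen at this one place, so it remains open whether a larger or differently charged group on the same aromatic carbon, such as a methoxy group, an amine or a carboxylic acid, would also stay within the scatter of compound 1. Also open, on these data alone, is whether the fluoro that remains in compound 4, meta to the position changed here, can leave with as little consequence, as a plain phenyl group in its place would show.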